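One Fluorine Fewer: From Compound 2 to Compound 3

The compounds below may be only part of what the source reports. "The series", "measured", "known", "first", "only" and "open" are said of these compounds alone.

Of the compounds shown here, two have been measured in a toxicity assay on the whole organism (strain CD-1) for cytotoxicity, with Mus musculus as the target, with a stated time of 14 days, at a dose of 300 mg/kg by the intraperitoneal route; on this read-out lower numbers stand for a stronger effect and higher numbers for a weaker effect at the one dose given. Compound 1 `O=C(O)c1ccc(F)c(F)c1O` gives 33%. Compound 2 `CC(=O)Oc1c(C(=O)O)cc(F)c(F)c1F` gives 0%, the lowest of the two numbers, and its gap to compound 1 lies beyond the scatter. Compound 3 `CC(=O)Oc1c(C(=O)O)ccc(F)c1F` has not yet been measured. The change from compound 2 to compound 3 is hydrogen in place of fluoro on an aromatic carbon. Within the data shown here, no step of this kind has been measured here, so compound 3 is expected to shift toward compound 1 by a modest amount, a number 15 percentage points higher from compound 2 to compound 3 (beyond the scatter), in this assay. Compound 3 is therefore estimated at 15%, with a range from 0% to 40%.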

Compound 3, a percentage reported as activity, at one dose (the size of the read-out at that dose, not a potency): 33%
For compound 3 the middle estimate is 18 percentage points below the measured one; the range from low to high includes it.
By their numbers in this assay, from the lowest: compound 2; then compounds 1 and 3 (each within the scatter of the next).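

In this assay, hydrogen in place of fluoro on an aromatic carbon, ortho to a fluoro group and para to an acetoxy group, gives a number 33 percentage points higher from compound 2 to compound 3 (beyond the scatter), so this single position matters strongly on this read-out. Acetyl in place of hydrogen on the oxygen gives no change at the digits printed from compound 1 to compound 3 (within the scatter), a step that the earlier pair, differing in two places, could not isolate. No measurement here accounts for either step. From the compounds shown here alone, whether a chloro or methoxy group at this position would read like fluoro or like hydrogen stays open. So does whether a longer chain, such as butyryl, on the oxygen would match acetyl.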